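Fluoro on the benzyl ring of compound 1

This account rests on a few compounds, and the source may have more. Where it says the series, first, only, none or still open, it means among the compounds named here.

In a functional assay on the whole organism with Rattus norvegicus as the target, at a dose of 40 mg/kg by the intraperitoneal route (a lower number here means less inhibition, a higher number more inhibition at the dose given (going by the name of the read-out)), compound 1 `Cc1nc2c(OCc3ccccc3)cccn2c1N` gives 99%, the highest of the three measured numbers. Compound 2 `Nc1cnc2c(OCc3ccccc3)cccn12` gives 32% and compound 3 `CCCCc1nc2c(OCc3ccccc3)cccn2c1N` gives 26%. Both measured steps away from compound 1 are large and downward: a number 67 percentage points lower from compound 1 to compound 2 (beyond the scatter), hydrogen in place of methyl on an aromatic carbon, and a number 73 percentage points lower from compound 1 to compound 3 (beyond the scatter), propyl in place of hydrogen on a saturated chain carbon bound to an aromatic carbon. Between the two lower compounds the step of a number 6 percentage points lower from compound 2 to compound 3 (within the scatter), butyl in place of hydrogen on an aromatic carbon, stays within the scatter.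

Compound 4 `Cc1nc2c(OCc3ccc(F)cc3)cccn2c1N` differs from compound 1 by fluoro in place of hydrogen on an aromatic carbon. Among the compounds with values here, every measured step alters the group on the shared core; none touches the six-membered aromatic ring of carbon only, so no measured step bears on this change and nothing about substitution on that ring is known from the series. The number for compound 1 sits near the top of the scale, so there is room only to stay or to fall. Compound 4 is therefore expected to keep most of the inhibition, with a step of a number 14 percentage points lower from compound 1 to compound 4 (beyond the scatter) that may lie within the scatter or be modestly downward. The estimate for compound 4 is 85%, in the range 50% to 100%.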

Compound 4, a percentage reported as inhibition, in the whole organism at one dose (the size of the read-out at that dose, not a potency): 95%
Estimate against measurement, compound 4: 10 percentage points below; the measured number falls inside the stated range.
By their numbers in this assay, from the lowest: compounds 3 and 2 (each within the scatter of the next); then compounds 4 and 1 (each within the scatter of the next).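

Notes on the benzyl ring: in this assay, fluoro in place of hydrogen on an aromatic carbon of the six-membered aromatic ring of carbon only, para to a large group, gives a number 4 percentage points lower from compound 1 to compound 4 (within the scatter). Within the data shown here, this is the only step away from compound 1 that stays within the scatter, whereas the two changes on the shared core give a number 67 percentage points lower from compound 1 to compound 2 (beyond the scatter) and a number 73 percentage points lower from compound 1 to compound 3 (beyond the scatter), so this one position accepts this one replacement at the dose given. No measurement accompanies the result that would account for it.

As a single-dose read-out, the assay places compound 1 at 99% and compound 4 at 95%, both close to the top of the scale, so it leaves open whether the two differ in potency. Also open, as far as these compounds go, is whether chloro, methoxy, trifluoromethyl or an amine at this same place, or fluoro elsewhere on this ring, would stay within the scatter of compound 1 as well.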